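A few compounds are considered here, and "the series" means these few. Any claim that something is new, unique, unknown or untested is made for them only; others in the source may bear on it.

Compound 1 `COc1cc2c(Oc3ccc(NC(=O)c4cc(-c5ccc(F)cc5)ccn4)cc3F)ccnc2cc1OCCCN1CCCCC1` and compound 2 `COc1cc2c(Oc3ccc(NC(=O)c4cc(-c5ccc(C)cc5)ccn4)cc3F)ccnc2cc1OCCCN1CCCCC1` share one core and differ at a single group. In a functional assay on MKN-45 cells (Homo sapiens) for cytotoxicity, read by MTT assay, with a stated time of 72 h (on this read-out lower numbers stand for stronger inhibition and higher numbers for weaker inhibition), compound 2 gives 1670 nM, while compound 1 gives 1240 nM; the change fluoro in place of methyl on an aromatic carbon made a step of a 1.3-fold lower number from compound 2 to compound 1 (0.13 log units; within the scatter). Compound 3 `COc1cc2c(Oc3ccc(NC(=O)c4nccc(-c5ccc(C)cc5)n4)cc3F)ccnc2cc1OCCCN1CCN(C)CC1` rests on a different core, and the difference between the two cores is not broken down here. In this assay compound 3 gives 340 nM, the lowest of the three numbers. Compound 4 `COc1cc2c(Oc3ccc(NC(=O)c4nccc(-c5ccc(F)cc5)n4)cc3F)ccnc2cc1OCCCN1CCN(C)CC1` carries the same change on the core of compound 3, namely (fluoro in place of methyl on an aromatic carbon). Since this change gave a 1.3-fold lower number from compound 2 to compound 1 (0.13 log units; within the scatter), a step of similar, small size is expected now. On that footing the expected step is a 1.3-fold lower number from compound 3 to compound 4 (0.10 log units; within the scatter). Compound 4 is therefore estimated at 270 nM, with a range from 130 nM to 560 nM.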

Compound 4, half-maximal inhibitory concentration: 90 nM
Compound 4: middle estimate off by 3.0-fold (0.48 log units), on the high side, and the stated range ends above it.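

In this assay, replacing 4-methylphenyl with 4-fluorophenyl on the core of compound 3 gave a 3.8-fold lower number from compound 3 to compound 4 (0.58 log units; beyond the scatter). Going by these compounds alone, the size of this step therefore did not carry over from the first core to the second: the same change on two cores in this assay, a 1.3-fold lower number (0.13 log units; within the scatter) from compound 2 to compound 1 and a 3.8-fold lower number (0.58 log units; beyond the scatter) from compound 3 to compound 4, 2.8-fold (0.45 log units) apart, beyond the scatter of two such steps This rests on only one pair of compounds per core, so it shows that the step can depend on the core, but it does not show which part of the core matters or what the change would do on a third core.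

The compounds shown leave open how a chloro, methoxy or trifluoromethyl group in the same place would behave on these two cores. Going by these compounds, it also remains open whether such groups would show the same gap between cores.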